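Halogen swap on the aryl group of compound 2

The source may report more compounds than this note shows. Statements on the series, on what has been measured and on what is new or still open speak of the compounds shown alone.

Two compounds of this series have numbers in a functional assay on HT-29 cells (Homo sapiens) for cytotoxicity, read by MTT assay, with a stated time of 72 h; a lower number here means a stronger inhibitor, a higher number a weaker inhibitor. Compound 1 `COc1cc2c(Oc3ccc(NC(=O)c4nn(-c5cccc(F)c5)c(=O)c5ccccc45)cc3F)ccnc2cc1OCCCN1CCCC1` gives 460 nM. Compound 2 `COc1cc2c(Oc3ccc(NC(=O)c4nn(-c5ccccc5F)c(=O)c5ccccc45)cc3F)ccnc2cc1OCCCN1CCCC1` gives 400 nM. For the measured compounds named here, the one step between them, a 1.2-fold lower number from compound 1 to compound 2 (0.06 log units; within the scatter), leaves compound 2 and compound 1 within the scatter of each other, so neither can be set above the other.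

Compound 3 `COc1cc2c(Oc3ccc(NC(=O)c4nn(-c5ccc(Br)cc5)c(=O)c5ccccc45)cc3F)ccnc2cc1OCCCN1CCCC1` differs from compound 2 in one place: 4-bromophenyl in place of 2-fluorophenyl on an aromatic nitrogen. Going by the values given here, no measured step moves a halogen around this ring in this way; the only step at hand, from compound 1 to compound 2, shifted a fluorine and gave no change beyond the scatter. On that basis the expected step of a 1.1-fold higher number from compound 2 to compound 3 (0.05 log units; within the scatter) in this assay is none beyond the scatter, with the range widened for the untested bromine. Compound 3 is therefore estimated at 450 nM, between 180 nM and 1100 nM.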

Compound 3, half-maximal inhibitory concentration: 670 nM
Compound 3: middle estimate off by 1.5-fold (0.17 log units), on the low side, and the stated range covers the measured number.
By their numbers in this assay, from the lowest: compounds 2, 1 and 3 (each within the scatter of the next).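

In this assay, a 1.7-fold higher number from compound 2 to compound 3 (0.22 log units; within the scatter) and a 1.5-fold higher number from compound 1 to compound 3 (0.16 log units; within the scatter) both stay within the scatter, so on this aromatic nitrogen the 4-bromophenyl cannot be told apart from either fluorophenyl group. The earlier compounds shown here showed this only for a fluorine shifted around the ring; it now also holds for a change of halogen, with the heavy-atom count of the group unchanged. Nothing at hand bears on why these steps are small.

In this change the halogen and its place on the ring differ together, so their separate contributions remain unresolved. Also open, from the compounds shown here alone, is whether a non-halogen group on this ring, such as an amine or a carboxylic acid, or a longer chain on the nitrogen in place of the aryl group, would give a step beyond the scatter.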